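Naphthalen-2-yl replacing the carboxy tail of compound 1

This account rests on a few compounds, and the source may have more. Where it says the series, first, only, none or still open, it means among the compounds named here.

Compound 1 `O=C(O)CCCO/N=c1/ccn([C@@H]2O[C@H](COP(=O)(O)OP(=O)(O)OP(=O)(O)O)[C@@H](O)[C@H]2O)c(=O)[nH]1` carries a carboxy group at the end of the oxime-linked chain on the shared core. In a functional assay on 1321-N1 cells for agonist activity at P2Y purinoceptor 2 (Homo sapiens), read by scintillation counting and inositol phosphate accumulation (on this read-out higher numbers stand for an effect only at larger amounts of compound and lower numbers for an effect already at smaller amounts), compound 1 gives 299 nM, the highest of the two numbers recorded so far. Its nearest neighbour is compound 2 `C#CCCCO/N=c1/ccn([C@@H]2O[C@H](COP(=O)(O)OP(=O)(O)OP(=O)(O)O)[C@@H](O)[C@H]2O)c(=O)[nH]1`, which in this assay gives 168 nM; the step of a 1.8-fold lower number from compound 1 to compound 2 (0.25 log units; within the scatter) is within the scatter, so the two compounds cannot be ordered against each other.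

Compound 3 `O=c1[nH]/c(=N\OCCCc2ccc3ccccc3c2)ccn1[C@@H]1O[C@H](COP(=O)(O)OP(=O)(O)OP(=O)(O)O)[C@@H](O)[C@H]1O` is the next member. Its difference from compound 1 is naphthalen-2-yl in place of carboxy on a saturated chain carbon, three bonds along the chain from an oxygen on an unsaturated carbon. Among the measured compounds shown here, only one measured step bears on this change, namely a 1.8-fold lower number from compound 1 to compound 2 (0.25 log units; within the scatter), which shows that swapping the carboxy group for a small uncharged ethynyl group leaves the number essentially where it was. For the measured compounds named here, no measured compound carries an aromatic group at this position, so the naphthalen-2-yl change is not covered by any recorded step. On that basis the step of a 1.2-fold lower number from compound 1 to compound 3 (0.08 log units; within the scatter) is expected to stay close to the scatter, with a wide range to allow for the untested group. For compound 3 the estimate in this assay is therefore 250 nM, within 60 nM to 1000 nM.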

Compound 3, half-maximal effective concentration: 139 nM
Compound 3: the middle estimate sits 1.8-fold (0.25 log units) above what was measured, within the range that was stated.
By their numbers in this assay, from the lowest: compounds 3, 2 and 1 (each within the scatter of the next, the first and the last beyond it).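

In this assay, among the compounds shown here, naphthalen-2-yl is the first aromatic group seen on a saturated chain carbon, three bonds along the chain from an oxygen on an unsaturated carbon, and the number does not rise with it (the change from carboxy gives a 2.2-fold lower number from compound 1 to compound 3 (0.33 log units; beyond the scatter)), a modest step and the only one so far beyond the scatter. Set against ethynyl, the same group gives no separation (the change gives a 1.2-fold lower number from compound 2 to compound 3 (0.08 log units; within the scatter)), so 2 six-membered aromatic rings of carbon only and the small ethynyl group cannot be told apart at this place. No supporting data bear on why the carboxy step reaches beyond the scatter with naphthalen-2-yl and stays within it with ethynyl.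

The compounds shown leave open whether a phenyl ring on the same chain would fall with compound 3 or with compound 1, and whether an amine at the chain end would read like the carboxy group. Also open, going by these compounds, is what a longer chain or a shorter chain carrying naphthalen-2-yl would give in this assay on the shared core.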